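This account rests on a few compounds, and the source may have more. Where it says the series, first, only, none or still open, it means among the compounds named here.

Compound 1 `O=C(Nc1ccc(Cl)c(-c2nnc3c(Cl)cccn23)c1)c1ccc(C(F)(F)F)cc1Cl`: > 100000 nM
Compound 2 `O=C(Nc1ccc(Cl)c(-c2nnc3c(Cl)cccn23)c1)c1cccnc1`: > 100000 nM
Compound 3 `O=C(Nc1ccc(Cl)c(-c2nnc3c(Cl)cccn23)c1)c1ccccc1`: 67600 nM

Of the compounds shown here, three sharing one core have been tested in a functional assay on AN3-CA cells (Homo sapiens) for antiproliferative activity, read by MTT assay, with a stated time of 72 h; a higher number here means a weaker inhibitor, a lower number a stronger inhibitor. Compound 1 returns only a limit of the assay, > 100000 nM. Compound 2 likewise gives a limit, > 100000 nM. Among the compounds with values here, compound 3 is the one compound with a number, 67600 nM, and so it stands alone among the values shown. Compound 1 and compound 2 sit at the limit, as the evidence on the measured steps records: the limit of > 100000 nM in this assay, at which 2 of the 3 values shown sit. Within the data shown here, the single step with a computed size, an at least 1.4-fold lower number from compound 2 to compound 3 (0.17 log units; that floor lies within the scatter), has a floor within the scatter and says little about how large any further change might be.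

Compound 4 `O=C(Nc1ccc(Cl)c(-c2nnc3c(Cl)cccn23)c1)c1ccccc1Cl` differs from compound 3 by chloro in place of hydrogen on an aromatic carbon. Among the measured compounds shown here, no measured step alters that ring in the same way; compound 1 carries a chloro on the same ring together with a trifluoromethyl, and since its value is a limit, its gap to compound 3 cannot be sized. For compound 4 a small step, a 1.3-fold higher number from compound 3 to compound 4 (0.10 log units; within the scatter), toward a weaker number is expected, with a real chance that only a limit is reported. The estimate for compound 4 is 85000 nM, with a range from 30000 nM to 250000 nM.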

Compound 4, half-maximal inhibitory concentration: > 100000 nM
Compound 4 was reported as a limit (the forecaster's own chance of this, stated with the estimate: 45%); middle value at least 1.1-fold (0.07 log units) from the limit.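

In this assay compound 4 returns only a limit of the assay, > 100000 nM. Chloro on this aromatic carbon, ortho to a large group, is the first change to the phenyl ring that can be read on its own, and it gives an at least 1.4-fold higher number from compound 3 to compound 4 (0.17 log units; that floor lies within the scatter), so the direction is known while the floor alone does not separate the two compounds. The steps from compound 1 and from compound 2 to compound 4 cannot be read, and compound 3 remains the only compound with a number: the limit of > 100000 nM in this assay, at which 3 of the 4 values shown sit.

The compounds shown leave open whether a fluoro, a methyl or an amine on this same carbon would give a number in this assay or would also return a limit. As far as these compounds go, they also leave open how far compound 4 lies beyond its limit, so the full size of its step from compound 3 remains unknown.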